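This account rests on a few compounds, and the source may have more. Where it says the series, first, only, none or still open, it means among the compounds named here.

Measured in a functional assay on A549 cells (Homo sapiens) for antiproliferative activity, read by MTT assay; on this read-out lower numbers stand for stronger inhibition and higher numbers for weaker inhibition:
- compound 1 `COc1cc2c(Oc3ccc(NC(=O)Nc4ccc(OC(F)(F)F)cc4)cc3)ccnc2cc1OCCCCCCC(=O)NO`: 3130 nM
- compound 2 `COc1cc2c(Oc3ccc(NC(=O)Nc4ccc(C(F)(F)F)cc4Cl)cc3)ccnc2cc1OCCCCCCC(=O)NO`: 970 nM
- compound 3 `COc1cc2c(Oc3ccc(NC(=O)Nc4ccc(C)cc4C)cc3)ccnc2cc1OCCCCCCC(=O)NO`: 5490 nM

Compound 1 stands in the upper part of these numbers: a 1.8-fold higher number from compound 1 to compound 3 (0.24 log units; within the scatter), while a 3.2-fold lower number from compound 1 to compound 2 (0.51 log units; beyond the scatter). The next change leads to compound 4 `COc1cc2c(Oc3ccc(NC(=O)N/N=C/c4ccccc4)cc3)ccnc2cc1OCCCCCCC(=O)NO`: a group of 8 heavy atoms (7 carbon, 1 nitrogen; one six-membered aromatic ring of carbon only) in place of a group of 11 heavy atoms (7 carbon, 1 oxygen, 3 fluorine; one six-membered aromatic ring of carbon only), on an amide-type nitrogen. It sits on an amide-type nitrogen, the same place as the measured changes, which reach at most a 5.7-fold higher number from compound 2 to compound 3 (0.75 log units; beyond the scatter). None of them brings in the entering group, which has 1 double bond outside aromatic rings, so they guide only the size of the step. No clear direction follows in this assay, and a change beyond the scatter is not expected. The expected result is a 1.1-fold higher number from compound 1 to compound 4 (0.05 log units; within the scatter). For compound 4 the estimated value is 3500 nM, with an expected range of 1100 nM to 11000 nM.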

Compound 4, half-maximal inhibitory concentration: 3700 nM
The estimate for compound 4 lay 1.1-fold (0.02 log units) below the measured number; low and high end bracket the measured number.
By their numbers in this assay, from the lowest: compound 2; then compounds 1, 4 and 3 (each within the scatter of the next).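

In this assay, the entering group, with its double bond outside the aromatic ring, brings a new type of group to this amide-type nitrogen, yet it stays within the scatter of two earlier groups: a 1.2-fold higher number from compound 1 to compound 4 (0.07 log units; within the scatter) and a 1.5-fold lower number from compound 3 to compound 4 (0.17 log units; within the scatter). Only 2-chloro-4-(trifluoromethyl)phenyl remains separated from it, with a 3.8-fold higher number from compound 2 to compound 4 (0.58 log units; beyond the scatter). No supporting data explain these steps.

From the compounds shown here alone, whether chloro or trifluoromethyl on the ring of the entering group would close that gap remains open. Going by these compounds, the effect of an amine or a carboxylic acid at this nitrogen also remains open.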